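Compound 2 to compound 3: a defined chain stereocentre

The source may report more compounds than this note shows. Statements on the series, on what has been measured and on what is new or still open speak of the compounds shown alone.

Going by the values given here, in a physicochemical assay for lipophilicity, read by HPLC, measured as octanol-water partition (on this read-out higher numbers stand for higher lipophilicity and lower numbers for lower lipophilicity), compound 2 `COCCC(Oc1ncnc2c1cnn2-c1ccccc1Cl)C(=O)Nc1ccc(C)cn1` gives 4.1, the higher of the two numbers so far. Compound 1 `Cc1csc(NC(=O)COc2ncnc3c2cnn3-c2ccccc2Cl)n1` gives 3.2, lower by an amount beyond the scatter. These two compounds differ in more than one place, so their gap says nothing about the next change.

Compound 3 `COCC[C@H](Oc1ncnc2c1cnn2-c1ccccc1Cl)C(=O)Nc1ccc(C)cn1` departs from compound 2 as follows: the two compounds have the same atoms and bonds; at least one stereo element is drawn with a configuration in one of them and without one in the other: 1 of 1 stereo elements differ; a stereocentre at a saturated chain carbon is drawn without a configuration in compound 2 and S in compound 3. The two compounds have the same atoms and bonds, and a stereocentre at a saturated chain carbon is drawn without a configuration in compound 2 and S in compound 3. Among the compounds with values here, no measured pair shows such a change, so the expectation rests on compound 2 at 4.1. In this assay, no step beyond the scatter is expected, in either direction. The estimated result is no change at the digits printed from compound 2 to compound 3 (within the scatter). For compound 3 the estimated value is 4.1, with an expected range from 3.8 to 4.4.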

Compound 3, distribution coefficient: 3.9
Beside the measured number, compound 3's estimate is 0.20 log units above it; measured number inside the range.
By their numbers in this assay, from the lowest: compound 1; then compounds 3 and 2 (each within the scatter of the next).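

In this assay, going by these compounds alone, the first pair that differs in one place gives a number 0.20 log units lower from compound 2 to compound 3 (within the scatter), so drawing the saturated chain carbon as S instead of leaving it undefined gives no step beyond the scatter. Unlike the gap between compounds 1 and 2, this step can be read at a single position, though it rests on one pair only. No other structural difference stands beside the step, and the pair's whole difference is this: the fact that one of compounds 2 and 3 is drawn with a defined configuration and the other without, at the place where they differ

As far as these compounds go, the R configuration at this carbon remains open, as does the make-up of compound 2, whose drawing states no configuration. Also open, from the compounds shown here alone, is how this assay responds when a longer chain or a chain ending in an amine replaces the present chain on this carbon.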